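A few compounds are considered here, and "the series" means these few. Any claim that something is new, unique, unknown or untested is made for them only; others in the source may bear on it.

Measured so far in an assay on HEK293 cells for inhibition of Fatty-acid amide hydrolase 1 (Homo sapiens), read by fluorescence; a lower number here means a stronger inhibitor, a higher number a weaker inhibitor:
compound 1 `c1ccc(-c2ccc3oc(NC4CCCCC4)nc3c2)cc1` — > 1000 nM
compound 2 `Cn1ccc2cc(-c3ccc4oc(Nc5ccccc5)nc4c3)ccc21` — 48 nM

The entry of compound 1 is a limit of the assay, not a number (the limit of > 1000 nM in this assay, at which 1 of the 2 values shown sits). Among the compounds with values here, compound 2 therefore holds the only number in this assay among the two. Compound 3 `COc1ccc(Nc2nc3cc(-c4ccc5c(ccn5C)c4)ccc3o2)cc1` differs from compound 2 by methoxy in place of hydrogen on an aromatic carbon. No measured pair here carries this change, so no shown step guides it. The expectation is a step of the size a 1.2-fold lower number from compound 2 to compound 3 (0.08 log units; within the scatter), within the usual scatter, with no clear direction. Compound 3 is thus estimated at 40 nM, between 12 nM and 130 nM.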

Compound 3, half-maximal inhibitory concentration: 280 nM
Compound 3: the middle estimate sits 7.0-fold (0.85 log units) below what was measured, and the stated range ends below it.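

In this assay, within the data shown here, going from anilino to (4-methoxyphenyl)amino gives a 5.8-fold higher number from compound 2 to compound 3 (0.77 log units; beyond the scatter), the first step that can be read. The aromatic carbon para to a large group is therefore not indifferent to substitution, although compound 3 still gives a number, 280 nM, in this assay. Nothing at hand accounts for the size or direction of this step.

From the compounds shown here alone, whether the weakening belongs to methoxy alone or to any group at this place remains open. A fluorine or a hydroxyl group on the same carbon would separate the two.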